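The compounds below may be only part of what the source reports. "The series", "measured", "known", "first", "only" and "open" are said of these compounds alone.

Working notes on the side chain at the nitrogen. Of the compounds shown here, three on the shared core have been measured: compound 1 `CCCCOC(=O)CN(c1ccccc1)[C@H]1c2cc(C#N)ccc2OC(C)(C)[C@@H]1O`, compound 2 `CCNC(=O)CN(c1ccccc1)[C@H]1c2cc(C#N)ccc2OC(C)(C)[C@@H]1O` and compound 3 `CC1(C)Oc2ccc(C#N)cc2[C@H](N(CC#N)c2ccccc2)[C@H]1O`. In a functional assay (aorta) with Rattus norvegicus as the target (on this read-out higher numbers stand for weaker inhibition and lower numbers for stronger inhibition), compound 1 gives 27000 nM. Compound 2 gives > 30000 nM, which is a limit and not a number. Compound 3 gives 59000 nM, the higher of the two actual numbers, and compound 1 is its nearest neighbour.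

Next is compound 4 `CC1(C)Oc2ccc(C#N)cc2[C@H](N(Cc2ncco2)c2ccccc2)[C@H]1O`, with 1,3-oxazol-2-yl in place of cyano on a saturated chain carbon bound to a nitrogen on an aromatic ring.

Going by the values given here, two measured steps bear on this change. The one at the same place is a 2.2-fold higher number from compound 1 to compound 3 (0.34 log units; beyond the scatter). The other, made further out on the same side chain, is an at least 1.1-fold higher number from compound 1 to compound 2 (0.04 log units; that floor lies within the scatter). Neither shows a large move, so little beyond the scatter is expected in this assay. A slight lean towards a lower number is expected, since compound 3 already stands at 59000 nM and replacing its cyano with butoxycarbonyl gave a 2.2-fold higher number from compound 1 to compound 3 (0.34 log units; beyond the scatter) in the reverse direction.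

An expected step of a 1.7-fold lower number from compound 3 to compound 4 (0.23 log units; within the scatter) follows. For compound 4 the estimated value is 35000 nM, with an expected range of 12000 nM to 90000 nM.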

Compound 4, half-maximal inhibitory concentration: > 30000 nM
Compound 4: a limit, no number; the forecaster's own chance of this, stated with the estimate: 30%; the middle value does not contradict the limit.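

In this assay compound 4 gives > 30000 nM, which is a limit and not a number. The one readable step is an at least 1.1-fold higher number from compound 1 to compound 4 (0.04 log units; that floor lies within the scatter); with 1,3-oxazol-2-yl, this is the first five-membered aromatic ring on the saturated chain carbon bound to a nitrogen on an aromatic ring among the compounds shown, and the floor of this step does not by itself separate it from butoxycarbonyl. The steps to compound 4 from compound 2 and from compound 3 cannot be read, so 1,3-oxazol-2-yl cannot be ordered against ethylcarbamoyl or cyano, because the values meet the assay's ceiling: the limit of > 30000 nM in this assay, at which 2 of the 4 values shown sit.

As far as these compounds go, it stays open whether any group at this place gives a number well under that of compound 1, which gives 27000 nM. A carboxylic acid, an amine or a longer chain on the same carbon would show whether this position can move the read-out beyond the scatter at all, and a true number for compound 4 would be needed to place 1,3-oxazol-2-yl against cyano.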